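Trimming the aromatic ether of compound 3

A few compounds are considered here, and "the series" means these few. Any claim that something is new, unique, unknown or untested is made for them only; others in the source may bear on it.

In a functional assay on SW1990 cells (Homo sapiens) for cytotoxicity, read by MTT assay, with a stated time of 48 h, in the presence of a further agent that is not named here (on this read-out higher numbers stand for weaker inhibition and lower numbers for stronger inhibition), compound 1 `O=C(c1ccc2cccc(OCc3ccc(B(O)O)cc3)c2n1)N1CCC(Oc2no[n+]([O-])c2S(=O)(=O)c2ccccc2)CC1` gives 3050 nM, compound 2 `O=C(c1ccc2cccc(O)c2n1)N1CCC(Oc2no[n+]([O-])c2S(=O)(=O)c2ccccc2)CC1` gives 790 nM and compound 3 `O=C(NCCCOc1no[n+]([O-])c1S(=O)(=O)c1ccccc1)c1ccc2cccc(OCc3ccc(B(O)O)cc3)c2n1` gives 1200 nM. The value of compound 3 thus lies within the usual scatter of that of compound 2, while compound 1 stands apart from it, beyond the scatter, with the higher number.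

Compound 4 `O=C(NCCCOc1no[n+]([O-])c1S(=O)(=O)c1ccccc1)c1ccc2cccc(O)c2n1` has not yet been measured. The change that leads to it from compound 3 is a hydrogen atom in place of a group of 10 heavy atoms (7 carbon, 1 boron, 2 oxygen; one six-membered aromatic ring of carbon only), on an oxygen on an aromatic ring.

Within the data shown here, only one measured step bears on this exchange: a 3.9-fold lower number from compound 1 to compound 2 (0.59 log units; beyond the scatter). It is the same exchange, made in a pair that carries a different part on the carbonyl. One modest step is thin evidence, so a similar but slightly smaller shift toward a lower number seems reasonable in this assay. The expected step is a 3.0-fold lower number from compound 3 to compound 4 (0.48 log units; beyond the scatter).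

For compound 4 the estimated value is 400 nM, with an expected range from 150 nM to 1000 nM.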

Compound 4, half-maximal inhibitory concentration: 1470 nM
Estimate against measurement, compound 4: 3.7-fold (0.57 log units) below; the whole stated range lies below it.
By their numbers in this assay, from the lowest: compounds 2, 3 and 4 (each within the scatter of the next); then compound 1.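

In this assay, the exchange of the group of 10 heavy atoms for a hydrogen atom on the core of compound 3 gives a 1.2-fold higher number from compound 3 to compound 4 (0.09 log units; within the scatter), so the clear step seen on the core of compound 1 does not carry over. The group of 10 heavy atoms goes with a higher number in compound 1 only, not in compound 3. The outcome of this exchange on an oxygen on an aromatic ring thus depends on the part carried on the carbonyl: the same change on two cores in this assay, a 3.9-fold lower number (0.59 log units; beyond the scatter) from compound 1 to compound 2 and a 1.2-fold higher number (0.09 log units; within the scatter) from compound 3 to compound 4, 4.7-fold (0.67 log units) apart, beyond the scatter of two such steps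

Only these two pairs bear on the exchange, and a hydrogen atom is the only replacement shown. On these data alone, whether a small methyl ether, or a benzyl ether lacking the boron, would follow the pattern of compound 1 or that of compound 3 remains open.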